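Acyl heteroaryl swap on a shared amidine core

The source may hold more compounds than are shown below. What is called first, only, known or untested is meant among the compounds shown, and "the series" means these compounds.

Compound 2 `C[C@@]1(c2cc(NC(=O)c3ncc(OCF)nc3N)ccc2F)C=C(CF)OC(N)=N1` and compound 1 `C[C@@]1(c2cc(NC(=O)c3cnc(C(F)F)cn3)ccc2F)C=C(CF)OC(N)=N1` share the same core and differ only in the aromatic group on the carbonyl carbon. In an ADME assay on microsomes from liver (Rattus norvegicus, strain Crj;CD(SD)) for metabolic stability, read by LC-MS, using NADPH, with a stated time of 30 min, tested at 0.1 uM (on this read-out lower numbers stand for a less stable compound and higher numbers for a more stable compound), compound 2 gives 35%, and compound 1 gives 44%; the step of a number 9 percentage points lower from compound 1 to compound 2 (within the scatter) leaves the two within the scatter of each other, so compound 2 cannot be set apart from compound 1 on these numbers.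

Compound 3 `COc1cc(C#N)cnc1C(=O)Nc1ccc(F)c([C@]2(C)C=C(CF)OC(N)=N2)c1` again keeps the core and alters only the group on the carbonyl carbon: 5-cyano-3-methoxypyridin-2-yl in place of 3-amino-5-(fluoromethoxy)pyrazin-2-yl on a carbonyl carbon. Within the data shown here, the one measured step that bears on this, a number 9 percentage points lower from compound 1 to compound 2 (within the scatter), was itself a swap of the aromatic group on the carbonyl carbon and stayed within the scatter. Among the measured compounds shown here, with only that step to go on, no change beyond the scatter is expected from compound 2 to compound 3 in this assay, and the step is estimated as a number 5 percentage points higher from compound 2 to compound 3 (within the scatter). Compound 3 is therefore expected to give about 40%, with a range from 20% to 60%.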

Compound 3, percent of the compound remaining: 60%
The estimate for compound 3 lay 20 percentage points below the measured number; low and high end bracket the measured number.
By their numbers in this assay, from the lowest: compounds 2 and 1 (each within the scatter of the next); then compound 3.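

In this assay, this place on a carbonyl carbon whose other neighbour is an amide-type nitrogen proves able to move the read-out beyond the scatter, which the earlier swap between compound 1 and compound 2 did not show: the change gives a number 25 percentage points higher from compound 2 to compound 3 (beyond the scatter) and a number 16 percentage points higher from compound 1 to compound 3 (beyond the scatter). The 5-cyano-3-methoxypyridin-2-yl group therefore sets compound 3 apart from both compounds with a pyrazin-2-yl group, whether the group it replaces is 3-amino-5-(fluoromethoxy)pyrazin-2-yl or 5-(difluoromethyl)pyrazin-2-yl. No measurement shown here explains why the number rises with this group.

The entering group brings a nitrile, a methoxy and a ring with one hetero atom together, so the compounds shown do not tell which of these features goes with the step. Also open, from the compounds shown here alone, is whether a chlorine in place of the nitrile, or an ethoxy in place of the methoxy, would keep the number with that of compound 3 or return it to those of compound 1 and compound 2.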